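Halogen swap on the aryl ring: compound 2 to compound 4

The source may hold more compounds than are shown below. What is called first, only, known or untested is meant among the compounds shown, and "the series" means these compounds.

Measured in a functional assay on PC-3 cells (Homo sapiens) for antiproliferative activity, read by MTT assay, with a stated time of 48 h; a lower number here means a stronger inhibitor, a higher number a weaker inhibitor:
- compound 1 `CC1(C)Cc2c(ccc(C(=O)/C=C/c3cn(-c4ccccc4)nc3-c3ccccc3)c2OCc2ccccc2)O1` gives only a limit, > 100000 nM.
- compound 2 `CC1(C)Cc2c(ccc(C(=O)/C=C/c3ccc(Cl)cc3)c2OCc2ccccc2)O1` gives only a limit, > 100000 nM.
- compound 3 `CC1(C)Cc2c(ccc(C(=O)/C=C/c3cn(-c4ccccc4)nc3-c3ccc(Cl)cc3)c2OCc2ccccc2)O1` gives 26000 nM.

Compound 2 thus stands at the limit of > 100000 nM in this assay, at which 2 of the 3 values shown sit, so no number is known for it, only that it lies beyond the reach of this assay. The unmeasured compound 4 `CC1(C)Cc2c(ccc(C(=O)/C=C/c3ccc(F)cc3)c2OCc2ccccc2)O1` differs from compound 2 by fluoro in place of chloro on an aromatic carbon.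

Within the data shown here, the only measured step is an at least 3.8-fold lower number from compound 1 to compound 3 (0.58 log units; beyond the scatter). It concerns chloro in place of hydrogen on a different ring of the shared core, not the exchange of one halogen for another, and compound 1 starts from the same limit as compound 2, so the step is itself only a bound. Among the measured compounds shown here, no measured step bears directly on the change from compound 2 to compound 4.

Without a numeric starting point and without a comparable step, compound 4 is expected to remain near the limit, with the step from compound 2 to compound 4 estimated as a step that the limit leaves unreadable from compound 2 to compound 4. Compound 4 is expected at 150000 nM, within 40000 nM to 600000 nM.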

Compound 4, half-maximal inhibitory concentration: 44200 nM
Beside the measured number, compound 4's estimate is 3.4-fold (0.53 log units) above it; measured number inside the range.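

In this assay, the exchange of chloro for fluoro on the aromatic ring gives the series its first step between two halogens at one place, an at least 2.2-fold lower number from compound 2 to compound 4 (0.35 log units; beyond the scatter). The earlier step, an at least 3.8-fold lower number from compound 1 to compound 3 (0.58 log units; beyond the scatter), had chloro entering in place of hydrogen on a different scaffold and the number falling, whereas here chloro leaves and the number also falls, so the listed compounds give no single direction for chloro across the two settings. The size of the new step is only a bound, and the value for compound 2 is a limit: the limit of > 100000 nM in this assay, at which 2 of the 4 values shown sit.

Still open, from the compounds shown here alone, is how far this place tolerates other groups, such as bromo, methoxy, an amine or a carboxylic acid, and where the unsubstituted phenyl falls relative to the 4-fluorophenyl group. Also open, going by these compounds, is whether fluoro in place of chloro lowers the number in the setting of compound 3, where the chlorophenyl sits on the larger heteroaromatic substituent of the shared core.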